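A few compounds are considered here, and "the series" means these few. Any claim that something is new, unique, unknown or untested is made for them only; others in the source may bear on it.

Compounds measured in a functional assay (blood) for inhibition, with Homo sapiens as the target; on this read-out higher numbers stand for weaker inhibition and lower numbers for stronger inhibition:
- compound 1 `CCCC(Oc1ccc2c(c1)c(SC(C)(C)C)c(CC(C)(C)C(=O)O)n2Cc1ccc(Cl)cc1)c1ccc2ccccc2n1`: > 3000 nM, a limit
- compound 2 `CC(C)(C)Sc1c(CC(C)(C)C(=O)O)n(Cc2ccc(Cl)cc2)c2ccc(OCc3ccc4cnccc4n3)cc12`: 980 nM
- compound 3 `CC(C)(C)Sc1c(CC(C)(C)C(=O)O)n(Cc2ccc(Cl)cc2)c2ccc(OCc3nc4cc(C(F)(F)F)ccc4s3)cc12`: > 3000 nM, a limit

Among the measured compounds shown here, compound 2 gives 980 nM, the only true number in this small set. The rest of the picture is the limit of > 3000 nM in this assay, at which 2 of the 3 values shown sit.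

The next compound to be tested is compound 4 `CC(C)(C)Sc1c(CC(C)(C)C(=O)O)n(Cc2ccc(Cl)cc2)c2ccc(OCc3cccc(Cl)n3)cc12`, which keeps the shared core of compound 2 and exchanges one group: a group of 7 heavy atoms (5 carbon, 1 nitrogen, 1 chlorine; one six-membered aromatic ring with 1 hetero atom) in place of a group of 10 heavy atoms (8 carbon, 2 nitrogen; 2 six-membered aromatic rings with 1 hetero atom each), on a saturated chain carbon bound to an oxygen on an aromatic ring. The incoming 6-chloropyridin-2-yl is therefore a single ring in place of two, on a saturated chain carbon bound to an oxygen on an aromatic ring.

For the measured compounds named here, no measured pair in this set differs in one place, so the data offer no direct guide to the size of this step. Going by the values given here, with compound 2 at 980 nM as the one number and no other compound giving a number, a small move toward weaker inhibition is expected, and it may stay within the scatter. The expected step is a 1.6-fold higher number from compound 2 to compound 4 (0.21 log units; within the scatter). For compound 4 the estimated value in this assay is 1600 nM, with an expected range from 600 nM to 4000 nM.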

Compound 4, half-maximal inhibitory concentration: 410 nM
For compound 4 the middle estimate is 3.9-fold (0.59 log units) above the measured one, outside the stated range (below it).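

Exchanging the two-ring group for the single ring of 6-chloropyridin-2-yl gives a 2.4-fold lower number from compound 2 to compound 4 (0.38 log units; beyond the scatter) in this assay and so shows that, on this saturated chain carbon bound to an oxygen on an aromatic ring, a second ring is not required for inhibition. Among the compounds shown here, the earlier compounds offered only one number and two limits, so this is the first change at this place whose size can be read. Nothing available here accounts for the size of this step.

From the compounds shown here alone, the part played by the chlorine remains open, and a plain pyridin-2-yl or a methoxy group in place of the chlorine would address it. Also open, going by these compounds, is how a methyl group on the saturated chain carbon would act alongside the single ring.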